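The source may hold more compounds than are shown below. What is called first, only, known or untested is meant among the compounds shown, and "the series" means these compounds.

Compounds measured in an assay on IM-9 cells for binding affinity to Substance-P receptor (Homo sapiens); on this read-out higher numbers stand for weaker inhibition and lower numbers for stronger inhibition: compound 1 `Cc1ccccc1-c1c(C(=O)N(C)Cc2ccccc2Cl)n(C)c(=O)c2ccccc12` gives 19 nM; compound 2 `CN(Cc1cc(C(F)(F)F)cc(C(F)(F)F)c1)C(=O)c1c(-c2ccc(F)cc2)c2cccnc2c(=O)n1C` gives 0.21 nM; compound 3 `Cc1cc(C)cc(CN(C)C(=O)Nc2c(-c3ccccc3)c3cc(C)c(C)cc3c(=O)n2C)c1` gives 28 nM.

Within this small set, compound 1 stands in the middle-to-upper part of the numbers. Its value and that of compound 3 lie within the usual scatter of each other, so nothing separates the two. Compound 2 sits far lower, well beyond the scatter, and is the strongest of the three.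

Compound 4 `Cc1ccccc1-c1c(C(=O)N(C)Cc2ccccc2)n(C)c(=O)c2ccccc12` is compound 1 with one change: hydrogen in place of chloro on an aromatic carbon, so that the 2-chlorobenzyl becomes a benzyl. Among the measured compounds shown here, no measured pair shows this exact step, so its size can only be guessed. Compound 4 is expected to lose some strength, a modest step of a 2.4-fold higher number from compound 1 to compound 4 (0.37 log units; beyond the scatter) that may still fall within the scatter, giving an estimated 45 nM with a range from 15 nM to 150 nM.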

Compound 4, half-maximal inhibitory concentration: 34 nM
Compound 4: middle estimate off by 1.3-fold (0.12 log units), on the high side; the range from low to high includes it.
By their numbers in this assay, from the lowest: compound 2; then compounds 1, 3 and 4 (each within the scatter of the next).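

In this assay, the change from 2-chlorobenzyl to benzyl gives a 1.8-fold higher number from compound 1 to compound 4 (0.25 log units; within the scatter), so this first matched pair shows no measurable role for the chloro at this position. On this core, the group can carry hydrogen or chloro on that aromatic carbon without the two compounds being told apart. Nothing available here speaks to the reason for this result.

Still open, on these data alone, is whether a different group on this carbon, such as methoxy or an amine, would shift the number beyond the scatter.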